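Removing the Sulfonyl Arm from the Strongest Compound

The source may hold more compounds than are shown below. What is called first, only, known or untested is meant among the compounds shown, and "the series" means these compounds.

Compound 1 `CC(=O)NC[C@H]1CC[C@H](Nc2nc(Nc3ccc(Cl)cc3)c3ccccc3n2)CC1`: 390 nM
Compound 2 `CNC[C@H]1CC[C@H](Nc2nc(Nc3ccc(Cl)cc3)c3ccccc3n2)CC1`: 510 nM
Compound 3 `Cc1ccc(S(=O)(=O)NC[C@H]2CC[C@H](Nc3nc(Nc4ccccc4)c4ccccc4n3)CC2)cc1`: 4 nM

In a functional assay on cells for antagonist activity at Neuropeptide Y receptor type 5 (Homo sapiens) (a higher number here means a weaker inhibitor, a lower number a stronger inhibitor), compound 3 gives the lowest number of the three, beyond the scatter from both compound 1 and compound 2. Compound 4 `c1ccc(Nc2nc(NC3CCCCC3)nc3ccccc23)cc1` keeps the shared core but carries hydrogen in place of (((4-methylphenyl)sulfonyl)amino)methyl on a saturated ring carbon. Among the compounds with values here, the only measured step, a 1.3-fold higher number from compound 1 to compound 2 (0.12 log units; within the scatter), swaps a small group at the end of that same arm and stays within the scatter; it says nothing about removing the arm entirely. Compound 1 and compound 2 differ from compound 3 in more than one place, yet both sit far weaker, so the arm appears to matter. Compound 4 is expected to lose potency, the estimated step being a 75-fold higher number from compound 3 to compound 4 (1.88 log units; beyond the scatter). For compound 4 the estimate is 300 nM, ranging from 40 nM to 3000 nM.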

Compound 4, half-maximal inhibitory concentration: 50 nM
Beside the measured number, compound 4's estimate is 6.0-fold (0.78 log units) above it, and the stated range covers the measured number.
By their numbers in this assay, from the lowest: compound 3; then compound 4; then compounds 1 and 2 (each within the scatter of the next).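

Within the data shown here, removing the (((4-methylphenyl)sulfonyl)amino)methyl group from the saturated ring carbon gives a 13-fold higher number from compound 3 to compound 4 (1.10 log units; beyond the scatter) in this assay, the first direct reading of what this whole arm contributes. The arm clearly adds potency, yet it is not required for activity, as compound 4 still gives 50 nM with only hydrogen in this place. No available evidence accounts for the size of this change. Which part of the arm carries the gain remains open, as does what a plain aminomethyl group or a carboxylic acid would give in this place.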